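This account rests on a few compounds, and the source may have more. Where it says the series, first, only, none or still open, it means among the compounds named here.

Measured so far:
compound 1 `COc1ccc(NC(=O)[C@H]2CCCN2C(=O)C2(c3cccc(Cl)c3)CCCC2)nc1` — 2 nM
compound 2 `COc1ccc(NC(=O)[C@H]2CCCN2C(=O)C2(c3ccccc3)CCCC2)cc1` — 79.4 nM
compound 3 `O=C(Nc1ccc2[nH]ncc2n1)[C@H]1CCCN1C(=O)C1(c2ccc(F)cc2)CCC1` — 0.126 nM

In an assay on isolated protein for inhibition of histone acetyltransferase p300 (Homo sapiens), with a stated time of 60 min (a lower number here means a stronger inhibitor, a higher number a weaker inhibitor), compound 2 gives 79.4 nM, the highest of the three numbers; the gaps to compound 1 and to compound 3 are both beyond the scatter. Compound 4 `COc1ccc(NC(=O)[C@H]2CCCN2C(=O)C2(c3ccc(Cl)cc3)CCCC2)cc1` differs from compound 2 by chloro in place of hydrogen on an aromatic carbon. Among the measured compounds shown here, no pair of measured compounds isolates this change. Compound 1, which carries a halogen on the aryl group, gives 2 nM, and compound 3, likewise halogenated, gives 0.126 nM, but each also differs from compound 2 in the amide-bearing ring and in the cycloalkyl ring size, so the halogen alone cannot be read off. A moderate step to a lower number is nevertheless expected, beyond the scatter, as the estimated step of a 4.0-fold lower number from compound 2 to compound 4 (0.60 log units; beyond the scatter). Compound 4 is thus expected to give 20 nM, within 6 nM to 60 nM.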

Compound 4, half-maximal inhibitory concentration: 7.94 nM
Beside the measured number, compound 4's estimate is 2.5-fold (0.40 log units) above it, within the range that was stated.
By their numbers in this assay, from the lowest: compound 3; then compound 1; then compound 4; then compound 2.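

Phenyl to 4-chlorophenyl gives the first isolated reading at this position: with the rest of compound 2 held fixed, chloro in place of hydrogen brings a 10-fold lower number from compound 2 to compound 4 (1.00 log units; beyond the scatter) and this lies beyond the scatter. The aromatic carbon para to a large group therefore accepts a chlorine atom, and this single change lowers the number. No measurement at hand explains the step.

Open, going by these compounds, is whether an amine or a carboxylic acid on this same carbon would also lower the number. Also open, on these data alone, is whether the chloro step would carry over to the cores of compound 1 and compound 3.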